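Swapping an aryl for an ester on the shared core

A few compounds are considered here, and "the series" means these few. Any claim that something is new, unique, unknown or untested is made for them only; others in the source may bear on it.

Of the compounds shown here, three built on one shared core have been measured in an assay on microsomes from brain for inhibition of Fatty-acid amide hydrolase 1 (Rattus norvegicus), read by fluorescence and HPLC, with a stated time of 60 min; on this read-out lower numbers stand for stronger inhibition and higher numbers for weaker inhibition. For the measured compounds named here, compound 1 `CCCCCCCCc1ccc(OCC(=O)Cn2nnc(C)n2)cc1` gives 27 nM, and compound 2 `CCCCCCCCc1ccc(OCC(=O)Cn2nnc(-c3ccc(S(=O)(=O)N(C)C)cc3)n2)cc1` gives 590 nM; the single measured step between them, a 22-fold higher number from compound 1 to compound 2 (1.34 log units; beyond the scatter), shows the cost of a much larger group on that aromatic carbon. Going by the values given here, compound 3 `CCCCCCCCc1ccc(OCC(=O)Cn2nnnc2-c2ccccc2Cl)cc1` gives 4600 nM and stands with the highest number of the three, with compound 2 nearest and compound 1 furthest; no step is counted from compound 2 to compound 3, and their two values simply show compound 3 as the weaker inhibitor.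

Compound 4 `CCCCCCCCc1ccc(OCC(=O)Cn2nnnc2C(=O)OC)cc1` has not yet been measured. It differs from compound 3 by methoxycarbonyl in place of 2-chlorophenyl on an aromatic carbon. Among the compounds with values here, the only measured step that bears on a change of group size on the core is a 22-fold higher number from compound 1 to compound 2 (1.34 log units; beyond the scatter), in which the larger group gave the higher number. Compound 4 moves the other way, from a seven-atom aromatic group to a four-atom ester, so a lower number than that of compound 3 is expected, though the new group resembles neither of the measured ones and the size of the gain is uncertain. Compound 4 is therefore estimated at 1500 nM, within a range from 400 nM to 6000 nM. This estimate amounts to a 3.1-fold lower number from compound 3 to compound 4 (0.49 log units; beyond the scatter).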

Compound 4, half-maximal inhibitory concentration: 1000 nM
For compound 4 the middle estimate is 1.5-fold (0.18 log units) above the measured one; the measured number falls inside the stated range.
By their numbers in this assay, from the lowest: compound 1; then compounds 2 and 4 (each within the scatter of the next); then compound 3.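

In this assay, the aromatic carbon of the five-membered aromatic ring with 4 nitrogen now has a second measured group, and the change gives a 4.6-fold lower number from compound 3 to compound 4 (0.66 log units; beyond the scatter); this carbon therefore tolerates methoxycarbonyl better than 2-chlorophenyl. The gain is only partial, as the comparison with the core of compound 1 gives a 37-fold higher number from compound 1 to compound 4 (1.57 log units; beyond the scatter) for 5-(methoxycarbonyl)-1H-tetrazol-1-yl in place of 5-methyl-2H-tetrazol-2-yl, so compound 4 remains far from compound 1 even with the smaller group. Nothing available here accounts for either step.

The change from 2-chlorophenyl to methoxycarbonyl alters the heavy-atom count, the ring and the hydrogen-bond acceptors all at once, so the compounds shown cannot say which of these differences goes with the lower number. Also open, from the compounds shown here alone, is how a methyl, a carboxylic acid or a primary amide would read on this same carbon, any of which would help separate those differences and show whether compound 3 and compound 4 can be brought closer to compound 1.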